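The compounds below may be only part of what the source reports. "The series", "measured", "known", "first", "only" and "open" are said of these compounds alone.

Measured in a functional assay on HCT-116 cells (Homo sapiens) for inhibition, read by sulforhodamine B assay, with a stated time of 2 days; a lower number here means a stronger inhibitor of growth, a higher number a weaker inhibitor of growth:
compound 1 `CC1=C(C(=O)Nc2ccc(C)cc2)C(c2ccc(O)cc2O)NC(SCc2ccccc2)=N1`: 14500 nM
compound 2 `CC1=C(C(=O)Nc2cccc([N+](=O)[O-])c2)C(c2ccc(O)cc2O)NC(SCc2ccccc2)=N1`: 29000 nM
compound 3 `Cc1nc(S(=O)(=O)Cc2ccccc2)nc(-c2ccc(O)cc2O)c1C(=O)Nc1cccc([N+](=O)[O-])c1`: 10900 nM

Compound 2, at 29000 nM, stands at the high end of these three numbers. It is level within the scatter with compound 1, at 14500 nM, while compound 3, at 10900 nM, has a lower number beyond the scatter.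

The next compound, compound 4 `CC1=C(C(=O)Nc2cccc([N+](=O)[O-])c2)C(c2ccc(O)cc2O)NC(NN)=N1`, has aminoamino in place of benzylsulfanyl on a carbon with a double bond to nitrogen. The rest of compound 2 is kept.

Going by the values given here, only one measured step links compounds that differ in one place: a 2.0-fold higher number from compound 1 to compound 2 (0.30 log units; within the scatter). That step lies within the scatter, but it has 3-nitrophenyl in place of 4-methylphenyl on an amide-type nitrogen, so it does not touch the place that changes here. Among the compounds with values here, no measured compound shows what happens when benzylsulfanyl is replaced, which leaves neither size nor direction to carry over. The small step seen for compound 2 therefore supports only a weak expectation of no shift beyond the scatter in this assay, with real uncertainty on both sides.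

The expected step is a 1.5-fold lower number from compound 2 to compound 4 (0.16 log units; within the scatter). For compound 4 the estimated value is 20000 nM, with an expected range from 6000 nM to 70000 nM.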

Compound 4, concentration for 50% growth inhibition: 47700 nM
Estimate against measurement, compound 4: 2.4-fold (0.38 log units) below; the range from low to high includes it.
By their numbers in this assay, from the lowest: compounds 3, 1, 2 and 4 (each within the scatter of the next, the first and the last beyond it).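

Going by these compounds alone, at the carbon with a double bond to nitrogen, between two ring nitrogen atoms, compound 4 gives the first reading for a replacement of benzylsulfanyl in this assay (a 1.6-fold higher number from compound 2 to compound 4 (0.22 log units; within the scatter)), and this step lies within the scatter. In this one pair, therefore, exchanging benzylsulfanyl, with its six-membered aromatic ring of carbon only, for the much smaller ringless aminoamino leaves the number level with that of compound 2, and the aromatic ring is not required to keep it there. Nothing available explains why the two groups read alike.

Going by these compounds, whether a plain amine, methylsulfanyl or a longer chain such as hexylsulfanyl at this carbon would read differently remains open, since a single replacement cannot show how far this position tolerates change. On these data alone, it is also open whether aminoamino would behave in the same way with 4-methylphenyl on the amide-type nitrogen, as in compound 1, instead of the 3-nitrophenyl carried by compound 2 and compound 4.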